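A few compounds are considered here, and "the series" means these few. Any claim that something is new, unique, unknown or untested is made for them only; others in the source may bear on it.

Of the compounds shown here, three have so far been measured in a functional assay on MCF7 cells (Homo sapiens) for cytotoxicity, read by MTT assay, with a stated time of 72 h; a lower number here means a stronger inhibitor of growth, a higher number a weaker inhibitor of growth. Compound 1 `CCCCC[Se]c1nc([Se]CCCCC)c2cccnc2n1` gives 40800 nM. Compound 2 `CCCCCSc1nc(NCc2ccc([Se]C)cc2)c2ccccc2n1` gives 13000 nM. Compound 3 `CSc1nc(NCc2ccc([Se]C)cc2)c2ccccc2n1` gives 36400 nM, the second highest of the three numbers: its gap to compound 1 lies within the usual scatter of such measurements, while the step of a 2.8-fold higher number from compound 2 to compound 3 (0.45 log units; beyond the scatter) goes beyond it. That step replaces a butyl with a hydrogen on the chain carbon bound to sulfur, a part of the molecule that is not touched here.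

Compound 4 `CSc1ccc(CNc2nc(SC)nc3ccccc23)cc1` differs from compound 3 by a group of 2 heavy atoms (1 carbon, 1 sulfur; no ring) in place of a group of 2 heavy atoms (1 carbon, 1 selenium; no ring), on an aromatic carbon. For the measured compounds named here, no measured pair tests this exchange of a selenium-bearing group for a sulfur-bearing one on the ring; the single measured step concerns another part of the structure and offers no guide to direction. Compound 4 is therefore expected to stay close to compound 3, the expected step of a 1.0-fold lower number from compound 3 to compound 4 (0.00 log units; within the scatter) being one that does not go beyond the scatter. The estimate for compound 4 in this assay is 36000 nM, within a range from 12000 nM to 110000 nM.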

Compound 4, concentration for 50% growth inhibition: 47300 nM
Compound 4: the middle estimate sits 1.3-fold (0.12 log units) below what was measured, and the stated range covers the measured number.
By their numbers in this assay, from the lowest: compound 2; then compounds 3, 1 and 4 (each within the scatter of the next).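

In this assay, the step of a 1.3-fold higher number from compound 3 to compound 4 (0.11 log units; within the scatter) comes from placing methylsulfanyl where the selenium-bearing group stood, on the aromatic carbon para to a large group. Compound 3 and compound 4 therefore cannot be told apart in this read-out, so for this pair, sulfur serves as well as selenium at this position, which the earlier step, made at the chain on the other sulfur, could not show. Nothing available explains this result or says how the two compounds act in the cells.

From the compounds shown here alone, whether the same exchange would read alike in compound 2, with its longer chain on sulfur, stays open. So does how this assay would respond to a clearly different group at this ring position, such as an amine, a carboxylic acid or a longer chain on the sulfur.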